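What a bromo group might do to compound 3

This account rests on a few compounds, and the source may have more. Where it says the series, first, only, none or still open, it means among the compounds named here.

In a functional assay (uterus) for inhibition, with Rattus norvegicus as the target (a lower number here means that less compound is needed, a higher number that more compound is needed for the effect), compound 3 (`N#Cc1cn2ccncc2n1`) gives 2.38 nM and has the highest number of the three measured compounds. Compound 1 (`CCOC(=O)c1cn2c(Br)cncc2n1`) gives 1.02 nM and compound 2 (`NC(=O)c1cn2c(Br)cncc2n1`) gives 0.41 nM on the same scale. Both carry a bromo group that compound 3 lacks, but both also have a carbonyl group where compound 3 has its nitrile.

Compound 4 (`N#Cc1cn2c(Br)cncc2n1`) keeps that nitrile and changes one place: bromo in place of hydrogen on an aromatic carbon. This is bromo in place of hydrogen on an aromatic carbon.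

For the measured compounds named here, no measured step isolates this change. Going by the values given here, the only step, a 2.5-fold lower number from compound 1 to compound 2 (0.40 log units; beyond the scatter), is modest and swaps amino for ethoxy at another place, so it bears only indirectly. It does show how far the number can move among compounds with bromo. Since compound 1 and compound 2 both lie below compound 3, a modest fall is expected, with real uncertainty: a 2.6-fold lower number from compound 3 to compound 4 (0.42 log units; beyond the scatter) is the estimated step in this assay for this change.

The value estimated for compound 4 is 0.9 nM with an expected range from 0.3 nM to 2.6 nM in this measurement.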

Compound 4, concentration for half-maximal effect: 0.78 nM
Beside the measured number, compound 4's estimate is 1.2-fold (0.06 log units) above it; measured number inside the range.
By their numbers in this assay, from the lowest: compounds 2, 4 and 1 (each within the scatter of the next, the first and the last beyond it); then compound 3.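

With the nitrile held constant, the bromo group can now be read on its own: in this assay, a 3.1-fold lower number from compound 3 to compound 4 (0.48 log units; beyond the scatter), so this single change on the aromatic carbon moves the number modestly but beyond the scatter. Once bromo is present, the choice of group at the other place matters much less, since a 1.9-fold higher number from compound 2 to compound 4 (0.28 log units; within the scatter) and a 1.3-fold lower number from compound 1 to compound 4 (0.12 log units; within the scatter) both lie within the scatter, and the nitrile cannot be told apart from either carbonyl group. Nothing available gives a reason for the effect of the bromo group.

On these data alone, only hydrogen and bromo appear at this position, so it remains open how chloro, methyl or an amine there would compare. As far as these compounds go, the bromo step is also read only in compounds with the nitrile, so its size with the amide or the ethyl ester remains unknown.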